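A nitro to dimethylamino exchange on the shared core

A few compounds are considered here, and "the series" means these few. Any claim that something is new, unique, unknown or untested is made for them only; others in the source may bear on it.

Of the compounds shown here, three have so far been measured in an ADME assay on LLC-MK2 cells (Macaca mulatta) for cytotoxicity, read by MTT assay, with a stated time of 48 h; a higher number here means that more compound is tolerated, a lower number that less compound is tolerated. Compound 1 `C/C(=C\c1ccccc1)C(=O)/C=C/c1ccc([N+](=O)[O-])cc1` gives 43300 nM, compound 2 `C/C(=C\c1ccc([N+](=O)[O-])cc1)C(=O)/C=C/c1ccc([N+](=O)[O-])cc1` gives 32500 nM, and compound 3 `C/C(=C\c1ccc([N+](=O)[O-])cc1)C(=O)/C=C/c1ccc(N(C)C)cc1` gives 25900 nM. Compound 2 holds the middle of these three numbers, and its gaps to both of the others lie within the scatter.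

Still unmeasured is compound 4 `C/C(=C\c1ccc(N(C)C)cc1)C(=O)/C=C/c1ccc([N+](=O)[O-])cc1`. Its structure differs from that of compound 2 as follows: dimethylamino in place of nitro on an aromatic carbon. In words, this is dimethylamino in place of nitro on an aromatic carbon, para to a large group.

Among the compounds with values here, two measured steps bear on this change. The first, a 1.3-fold lower number from compound 1 to compound 2 (0.12 log units; within the scatter), concerns the same aromatic carbon, where nitro took the place of hydrogen. The second, a 1.3-fold lower number from compound 2 to compound 3 (0.10 log units; within the scatter), is the same exchange of groups, made on a different aromatic carbon of the shared core. Neither step goes beyond the scatter, so no step beyond it is expected here in this assay, and no direction can be claimed. The estimated step is a 1.2-fold lower number from compound 2 to compound 4 (0.06 log units; within the scatter). For compound 4 the expected value is 28000 nM, with an estimated range of 14000 nM to 55000 nM.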

Compound 4, half-maximal cytotoxic concentration: 167000 nM
Compound 4: the middle estimate sits 6.0-fold (0.78 log units) below what was measured, and the stated range ends below it.
By their numbers in this assay, from the lowest: compounds 3, 2 and 1 (each within the scatter of the next); then compound 4.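

In this assay, within the data shown here, dimethylamino in place of nitro on this aromatic carbon gives a 5.1-fold higher number from compound 2 to compound 4 (0.71 log units; beyond the scatter), the first step in this set that lies beyond the scatter. The comparison with hydrogen on the same carbon points the same way, with a 3.9-fold higher number from compound 1 to compound 4 (0.59 log units; beyond the scatter), so compound 4 stands apart from both the nitro and the hydrogen compounds, while those two remain within the scatter of each other. The same exchange of groups on the other aromatic carbon gives only a 1.3-fold lower number from compound 2 to compound 3 (0.10 log units; within the scatter), which lies within the scatter, so in this assay the outcome of the exchange depends on which aromatic carbon carries it, at least on this core.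

Nothing given here explains why dimethylamino raises the tolerated concentration on one aromatic carbon and not on the other. From the compounds shown here alone, it also remains open whether the higher number belongs to dimethylamino alone or would also appear with an unsubstituted amine, a methoxy group or a pyrrolidine on the same carbon.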